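This account rests on a few compounds, and the source may have more. Where it says the series, first, only, none or still open, it means among the compounds named here.

Compound 1 `O=C1c2ccccc2NS(=O)(=O)N1COCCO` and compound 2 `O=C1c2ccccc2N(COCc2ccccc2)S(=O)(=O)N1Cc1ccccc1` share the same core and were both tested in a functional assay on HEL cells (Homo sapiens); on this read-out lower numbers stand for higher toxicity in this test and higher numbers for lower toxicity in this test. In this assay compound 1 gives 160 ug/mL. For compound 2 the result is only a limit of the assay, > 50 ug/mL, so its true value is not known as a number. Compound 2 thus stands at the limit of > 50 ug/mL in this assay, at which 1 of the 2 values shown sits, and nothing more can be said about how it compares with compound 1. Compound 3 `O=C1c2ccccc2NS(=O)(=O)N1Cc1ccccc1` has not yet been measured. It differs from compound 2 by hydrogen in place of (benzyloxy)methyl on a sulfonamide nitrogen in a ring, so compound 3 keeps the benzyl group on the other ring nitrogen and carries a hydrogen where compound 2 had the larger group. Among the compounds with values here, with no measured step available, the change from compound 2 to compound 3 is expected to lie within the usual scatter, as a step that the limit leaves unreadable from compound 2 to compound 3. Compound 3 is therefore estimated at 120 ug/mL, with a likely range from 40 ug/mL to 300 ug/mL.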

Compound 3, half-maximal cytotoxic concentration: > 50 ug/mL
Compound 3: no number, only a limit (the forecaster's own chance of this, stated with the estimate: 40%); the middle value does not contradict the limit.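

In this assay compound 3 gives only a limit, > 50 ug/mL. Within the data shown here, no step from compound 1 or compound 2 to compound 3 can be read: the limit of > 50 ug/mL in this assay, at which 2 of the 3 values shown sit.

Still open, on these data alone, is how the true values of compound 2 and compound 3 compare with each other and with compound 1.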